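The source may report more compounds than this note shows. Statements on the series, on what has been measured and on what is new or still open speak of the compounds shown alone.

Measured so far in a functional assay on SK-MEL-147 cells (Homo sapiens) for cytotoxicity, read by MTT assay, with a stated time of 24 h; a lower number here means that less compound is needed, a higher number that more compound is needed for the effect:
compound 1 `CCOC(=O)c1cc([Te]c2ccccc2)c2cc(OC)ccc2n1`: 128000 nM
compound 2 `CCOC(=O)c1cc(C#Cc2ccc(N)cc2)c2cc(OC)ccc2n1`: 8800 nM
compound 3 `COc1ccc2nc(-c3c(Cl)cccc3Cl)cc([Se]c3ccccc3)c2c1`: > 150000 nM, a limit of the assay, not a number

Compound 1 gives 128000 nM in this assay, the higher of the two numbers shown, so more of it is needed than of compound 2, which gives 8800 nM. Compound 3 sits at the limit of > 150000 nM in this assay, at which 1 of the 3 values shown sits, which is a limit rather than a measured number. Compound 4 `CCOC(=O)c1cc([Se]c2ccc(F)cc2)c2cc(OC)ccc2n1` has not been measured yet. It differs from compound 1 in one place: a group of 8 heavy atoms (6 carbon, 1 fluorine, 1 selenium; one six-membered aromatic ring of carbon only) in place of a group of 7 heavy atoms (6 carbon, 1 tellurium; one six-membered aromatic ring of carbon only), on an aromatic carbon. Among the compounds with values here, no measured pair differs in just this way, so the size of the step cannot be read from the data. The step of a 1.1-fold lower number from compound 1 to compound 4 (0.03 log units; within the scatter) is expected to be small, not beyond the usual scatter. Compound 4 is therefore expected to give about 120000 nM, within a range from 50000 nM to 300000 nM.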

Compound 4, half-maximal effective concentration: > 150000 nM
Compound 4 gave a limit, no number (the forecaster's own chance of this, stated with the estimate: 35%); at least 1.2-fold (0.09 log units) between middle value and limit.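

On the aromatic carbon opposite the ring nitrogen, putting the group with selenium and fluorine in place of the group with tellurium gives, in this assay, an at least 1.1-fold higher number from compound 1 to compound 4 (0.06 log units; that floor lies within the scatter). On these data alone, compound 4 gives > 150000 nM, a limit of the assay and not a number, so this change brings no lower number, and its full size stays unknown. This limit now recurs among the compounds shown: the limit of > 150000 nM in this assay, at which 2 of the 4 values shown sit.

Selenium and fluorine change together here, so their separate effects cannot be read. As far as these compounds go, how a group with sulfur in place of selenium would behave at this carbon also remains open.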